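Ring Methylation of an N-Methylated Carboxamide

The compounds below may be only part of what the source reports. "The series", "measured", "known", "first", "only" and "open" are said of these compounds alone.

Measured compounds:
compound 1, `O=C(NCc1cc(C(F)(F)F)cc(C(F)(F)F)c1)c1cnc2ccccc2c1-c1ccccc1`, 208 nM
compound 2, `CN(Cc1cc(C(F)(F)F)cc(C(F)(F)F)c1)C(=O)c1cnc2ccccc2c1-c1ccccc1`, 92 nM

Both were tested in an assay on CHO cells for displacement of a labelled ligand from Substance-P receptor (Homo sapiens), with a stated time of 90 min; on this read-out higher numbers stand for weaker inhibition and lower numbers for stronger inhibition. Within the data shown here, compound 2 stands at the lower of the two numbers; the single measured step, a 2.3-fold lower number from compound 1 to compound 2 (0.35 log units; beyond the scatter), came from methyl in place of hydrogen on the amide-type nitrogen. Compound 3, `Cc1nc2ccccc2c(-c2ccccc2)c1C(=O)N(C)Cc1cc(C(F)(F)F)cc(C(F)(F)F)c1`, keeps that methylated amide and differs from compound 2 by methyl in place of hydrogen on an aromatic carbon, the carbon sitting next to the ring nitrogen and ortho to a large group. Among the measured compounds shown here, no measured step touches the ring itself, so the only step on record, a 2.3-fold lower number from compound 1 to compound 2 (0.35 log units; beyond the scatter), bears on this change merely as a sign that small changes around the amide shift the number modestly. Compound 3 is therefore expected to show a modest step of a 2.3-fold lower number from compound 2 to compound 3 (0.36 log units; beyond the scatter) in this assay, toward a lower number. The estimate for compound 3 is 40 nM, with a range from 10 nM to 160 nM.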

Compound 3, half-maximal inhibitory concentration: 19 nM
The estimate for compound 3 lay 2.1-fold (0.32 log units) above the measured number; measured number inside the range.
By their numbers in this assay, from the lowest: compound 3; then compound 2; then compound 1.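

Among these compounds, the aromatic carbon next to the ring nitrogen, untouched in the earlier compounds, proves to be a position where a single methyl moves the number in this assay, with a 4.8-fold lower number from compound 2 to compound 3 (0.69 log units; beyond the scatter). This step goes the same way as the earlier methyl on the amide-type nitrogen, a 2.3-fold lower number from compound 1 to compound 2 (0.35 log units; beyond the scatter), so both single-methyl changes shown lead to a lower number, and no compound shown goes against this. Nothing available explains why the number moved at this position.

From the compounds shown here alone, it remains open whether an ethyl group, an amine or a chlorine atom on this carbon would take the number lower or raise it again. Also open, going by these compounds, is whether the ring methyl would give a similar step with the amide hydrogen in place of the amide methyl.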